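The compounds below may be only part of what the source reports. "The series", "measured", "known", "first", "only" and "open" are said of these compounds alone.

Working notes on the series. In an ADME assay on microsomes from liver (Mus musculus) for pharmacokinetics, read by LC-MS, using NADPH, with stated times of 5 min, 15 min and 30 min, tested at 10 uM (on this read-out lower numbers stand for slow clearance and higher numbers for fast clearance), compound 1 `C[C@H](NC(=O)c1ncccn1)c1ccc(NC(=O)N2CC(c3cccnc3)C2)cc1` gives 28.9 mL.min-1.g-1. Compound 2 `C[C@H](NC(=O)c1cccc(F)c1)c1ccc(NC(=O)N2CC(c3ccc(N)nc3)C2)cc1` gives < 25 mL.min-1.g-1, which is a limit of the assay and not a number; this places it at the limit of < 25 mL.min-1.g-1 in this assay, at which 1 of the 2 values shown sits.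

Compound 3 `C[C@H](NC(=O)c1ncccn1)c1ccc(NC(=O)N2CC(c3ccc(N)nc3)C2)cc1` keeps the rest of compound 2 and carries one change: pyrimidin-2-yl in place of 3-fluorophenyl on a carbonyl carbon, with pyrimidin-2-yl in place of 3-fluorophenyl on a carbonyl carbon. Going by the values given here, no pair of measured compounds differs in this one place alone, so the size of the change has no direct precedent. Compound 1 carries the same pyrimidin-2-yl and gives 28.9 mL.min-1.g-1, which gives no reason to expect a large rise. In this assay the expected change is a step that the limit leaves unreadable from compound 2 to compound 3, estimated to stay within the usual scatter, with no firm direction. For compound 3 the estimated clearance is 23 mL.min-1.g-1, with an expected range of 12 mL.min-1.g-1 to 42 mL.min-1.g-1.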

Compound 3, intrinsic clearance in microsomes: < 25 mL.min-1.g-1
Compound 3: only a limit was reported (the forecaster's own chance of this, stated with the estimate: 55%); the middle value lies beyond the limit too.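

In this assay compound 3 returns a limit of the assay and not a number, as compound 2 does, so the step between them, pyrimidin-2-yl in place of 3-fluorophenyl on a carbonyl carbon, cannot be read in size or direction: the limit of < 25 mL.min-1.g-1 in this assay, at which 2 of the 3 values shown sit. Going by these compounds alone, the one readable comparison is the other one, amino in place of hydrogen on an aromatic carbon, which gives an at least 1.1-fold lower number from compound 1 to compound 3 (0.06 log units; that floor lies within the scatter) and so shows no change beyond the usual scatter, although the true step may be larger. Pyrimidin-2-yl on a carbonyl carbon is thus now seen both with and without that amino group.

As far as these compounds go, how far compound 2 and compound 3 lie past the limit stays open. Also open, from the compounds shown here alone, is where this assay would place a methoxy group or a carboxylic acid in place of the amino group.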